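A few compounds are considered here, and "the series" means these few. Any claim that something is new, unique, unknown or untested is made for them only; others in the source may bear on it.

In a functional assay on MGC-803 cells (Homo sapiens) for antiproliferative activity, read by CCK-8 assay, with a stated time of 72 h, tested at 8 uM (a lower number here means a weaker effect, a higher number a stronger effect of the compound at the concentration tested), compound 1 `CC1CCCCN1C(=S)SCc1ccc(C(=O)Nc2ccccc2N)cc1` gives 86.9%, and compound 2 `CCN(Cc1ccncc1)C(=S)SCc1ccc(C(=O)Nc2ccccc2N)cc1` gives 85.2%, a pair that stands within the scatter of each other, as a number 1.7 percentage points lower from compound 1 to compound 2 (within the scatter) shows. Compound 3 `CN(Cc1cccnc1)C(=S)SCc1ccc(C(=O)Nc2ccccc2N)cc1` is not yet measured in this assay; it differs from compound 2 by methyl((pyridin-3-yl)methyl)amino in place of ethyl((pyridin-4-yl)methyl)amino on a thiocarbonyl carbon. Among the measured compounds shown here, the only step that bears on this place on the thiocarbonyl carbon is a number 1.7 percentage points lower from compound 1 to compound 2 (within the scatter), which did not exceed the scatter, so no step beyond the scatter is expected here, a number 1.2 percentage points lower from compound 2 to compound 3 (within the scatter). Compound 3 is therefore estimated at 84%, between 72% and 94%.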

Compound 3, a percentage reported as inhibition, at one concentration (the size of the read-out at that concentration, not a potency): 85.5%
Compound 3: the middle estimate sits 1.5 percentage points below what was measured; the measured number falls inside the stated range.
By their numbers in this assay, from the lowest: compounds 2, 3 and 1 (each within the scatter of the next).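

In this assay, moving from ethyl((pyridin-4-yl)methyl)amino to methyl((pyridin-3-yl)methyl)amino on the thiocarbonyl carbon gives a number 0.3 percentage points higher from compound 2 to compound 3 (within the scatter), and replacing 2-methylpiperidin-1-yl with the same group gives a number 1.4 percentage points lower from compound 1 to compound 3 (within the scatter), so all three groups at this place read alike at the single concentration tested. No measurement offered here explains this likeness. The compounds shown leave open how the ethyl-to-methyl and pyridin-4-yl-to-pyridin-3-yl changes act separately, and whether a carboxylic acid or a longer chain at this place would hold the read-out.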